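The source may hold more compounds than are shown below. What is called first, only, known or untested is meant among the compounds shown, and "the series" means these compounds.

- Compound 1 `O=C(/C=C/c1cccc(OCc2ccccc2)c1)c1ccc([N+](=O)[O-])cc1` gives 82400 nM
- Compound 2 `O=C(/C=C/c1cccc(OCc2ccccc2)c1)c1ccc(Br)cc1` gives 9000 nM

Among the compounds with values here, in an ADME assay on CHO cells (Cricetulus griseus) for cytotoxicity, read by MTT assay, with a stated time of 68 h (on this read-out lower numbers stand for stronger inhibition and higher numbers for weaker inhibition), compound 1 gives 82400 nM, the higher of the two numbers so far. Compound 3 `Cc1ccc(C(=O)/C=C/c2cccc(OCc3ccccc3)c2)cc1` has not yet been measured. It differs from compound 1 by one change, methyl in place of nitro on an aromatic carbon. Within the data shown here, only one measured step replaces this nitro, namely a 9.2-fold lower number from compound 1 to compound 2 (0.96 log units; beyond the scatter), with bromo as the new group. That single step is thin evidence, but it points to a lower number. The expected step is therefore in the same direction and somewhat smaller: a 5.5-fold lower number from compound 1 to compound 3 (0.74 log units; beyond the scatter). Compound 3 is estimated at 15000 nM, with an expected range from 5000 nM to 50000 nM.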

Compound 3, half-maximal inhibitory concentration: 26400 nM
Compound 3: the middle estimate sits 1.8-fold (0.25 log units) below what was measured; the measured number falls inside the stated range.
By their numbers in this assay, from the lowest: compound 2; then compound 3; then compound 1.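

A second group in place of the nitro again brings a 3.1-fold lower number from compound 1 to compound 3 (0.49 log units; beyond the scatter) so the drop is not peculiar to bromo. The two replacements are not equivalent, with a 2.9-fold higher number from compound 2 to compound 3 (0.47 log units; beyond the scatter) as methyl takes the place of bromo, which shows that the entering group matters and not only the loss of nitro. No measurement at hand explains these differences. As far as these compounds go, whether an amine or a carboxylic acid at this place would give a number closer to compound 2 or to compound 1 remains open. Whether this order holds on any other core is also unknown.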